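One Methoxy Fewer: From Compound 2 to Compound 3

The source may hold more compounds than are shown below. What is called first, only, known or untested is meant among the compounds shown, and "the series" means these compounds.

Compound 1 `COc1ccc(-c2cc(/C=C/C(=O)c3ccc(N)cc3)[nH]n2)cc1`: 96%
Compound 2 `COc1cc(-c2cc(/C=C/C(=O)c3ccc(N)cc3)[nH]n2)cc(OC)c1OC`: 110%

In a functional assay on OVCAR-3 cells (Homo sapiens) for cytotoxicity, read by sulforhodamine B assay, with a stated time of 48 h, tested at 0.1 uM (on this read-out lower numbers stand for a stronger effect and higher numbers for a weaker effect at the one concentration tested), compound 1 gives 96%, and compound 2 gives 110%. Compound 2 stands highest of the two numbers; its nearest neighbour is compound 1, whose number lies lower by a gap beyond the usual scatter. Both numbers sit high on this read-out, so neither compound shows much of an effect at the single concentration tested.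

Compound 3 `COc1ccc(-c2cc(/C=C/C(=O)c3ccc(N)cc3)[nH]n2)cc1OC` differs from compound 2 by hydrogen in place of methoxy on an aromatic carbon. Among the measured compounds shown here, no step between measured compounds matches this change, so the expectation can rest only on where the two measured numbers lie. Compound 3 carries two methoxy groups, compound 2 carries three and compound 1 carries one, and the estimate for compound 3 is therefore placed between those two measured numbers, closer to compound 2. The expected step is small, downward and within the scatter: a number 7 percentage points lower from compound 2 to compound 3 (within the scatter). Compound 3 is estimated at 103%, with a range from 88% to 118%.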

Compound 3, a percentage reported as activity, at one concentration (the size of the read-out at that concentration, not a potency): 108%
Estimate against measurement, compound 3: 5 percentage points below; the range from low to high includes it.
By their numbers in this assay, from the lowest: compound 1; then compounds 3 and 2 (each within the scatter of the next).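

In this assay, hydrogen in place of methoxy on an aromatic carbon, at the place ortho to a methoxy group and meta to a large group, gives a number 2 percentage points lower from compound 2 to compound 3 (within the scatter), so at this place the read-out does not separate hydrogen from methoxy. The same kind of exchange starting from compound 1, methoxy in place of hydrogen on an aromatic carbon, gives a number 12 percentage points higher from compound 1 to compound 3 (beyond the scatter), a modest step, but one that, unlike the first, can be read, and it points toward a weaker effect at the one concentration tested. Thus a single swap of hydrogen and methoxy on this ring does not act the same in these two pairs, and nothing available explains the difference between them.

The compounds shown leave open whether a hydroxyl group, a chlorine atom or an amine at this place would read differently from hydrogen and methoxy. They also leave open whether the two steps would hold at other concentrations, since every number here comes from a single concentration at which all three compounds show little effect.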